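Amide in place of ester on a shared naphthyl core

The source may hold more compounds than are shown below. What is called first, only, known or untested is meant among the compounds shown, and "the series" means these compounds.

Among the measured compounds shown here, compound 3 `COC(=O)c1ccc2cc(C(O)(c3c[nH]cn3)C(C)C)ccc2c1` stands at the high end of the three numbers so far in an assay on microsomes from Testis (strain Sprague-Dawley) for inhibition of steroid 17-alpha-hydroxylase/17,20 lyase (Rattus norvegicus) (a higher number here means a weaker inhibitor, a lower number a stronger inhibitor), where compound 3 gives 43 nM. Compound 1 `CC(=O)c1ccc2cc(C(O)(c3c[nH]cn3)C(C)C)ccc2c1` gives 14 nM, and compound 2 `CCCNC(=O)c1ccc2cc(C(O)(c3c[nH]cn3)C(C)C)ccc2c1` gives 13 nM. The measured steps read a 3.1-fold higher number from compound 1 to compound 3 (0.49 log units; beyond the scatter), a 3.3-fold higher number from compound 2 to compound 3 (0.52 log units; beyond the scatter) and a 1.1-fold lower number from compound 1 to compound 2 (0.03 log units; within the scatter), so the ester sits apart from the ketone and the propyl amide, which lie within the scatter of each other.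

Compound 4 `CCNC(=O)c1ccc2cc(C(O)(c3c[nH]cn3)C(C)C)ccc2c1` differs from compound 3 by ethylamino in place of methoxy on a carbonyl carbon, that is, methoxycarbonyl to ethylcarbamoyl. The step from compound 2 to compound 3 is the one that bears on this change, and it ran beyond the scatter toward a higher number; the change to compound 4 runs the other way, to an amide shorter by one carbon than that of compound 2. Compound 4 is therefore expected to return to the level of compound 2, and the step from compound 3 to compound 4 is estimated at a 3.1-fold lower number from compound 3 to compound 4 (0.49 log units; beyond the scatter). Compound 4 is expected to give 14 nM in this assay, with a range from 7 nM to 30 nM.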

Compound 4, half-maximal inhibitory concentration: 11 nM
For compound 4 the middle estimate is 1.3-fold (0.10 log units) above the measured one; the range from low to high includes it.
By their numbers in this assay, from the lowest: compounds 4, 2 and 1 (each within the scatter of the next); then compound 3.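

Replacing methoxy with ethylamino on the carbonyl carbon gives (a 3.9-fold lower number from compound 3 to compound 4 (0.59 log units; beyond the scatter)) in this assay, so the ester now stands apart from two amides rather than one. The two amide chains cannot be told apart, since the step (a 1.2-fold lower number from compound 2 to compound 4 (0.07 log units; within the scatter)) shows that ethylamino and propylamino read alike here, and the ketone joins them with (a 1.3-fold lower number from compound 1 to compound 4 (0.10 log units; within the scatter)). Compound 3 therefore remains the only compound of the four set apart from the others, and no measurement shown here accounts for that.

Going by these compounds, it remains open whether a butylamino chain, an unsubstituted amide or a dimethylamino group on the same carbonyl carbon would stay level with compound 4. How a carboxylic acid in place of the ester would read in this assay is also unknown.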